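Cytotoxicity series: one methoxy removed from compound 2

The source may hold more compounds than are shown below. What is called first, only, known or untested is meant among the compounds shown, and "the series" means these compounds.

Measured compounds and values in a functional assay on UACC-62 cells (Homo sapiens) for cytotoxicity, read by sulforhodamine B assay, with a stated time of 48 h, tested at 1 uM; a higher number here means a weaker effect of the compound at the concentration tested, a lower number a stronger effect:
compound 1, `COc1cc(-c2cc(/C=C/C(=O)c3ccc(Cl)c(Cl)c3)[nH]n2)cc(OC)c1OC`, 96%
compound 2, `COc1ccc(C(=O)/C=C/c2cc(-c3cc(OC)c(OC)c(OC)c3)n[nH]2)cc1OC`, 95%

Compound 2 and compound 1 give numbers that lie within the scatter of each other, so nothing separates them on the data in hand. Among the measured compounds shown here, the only measured step, a number 1 percentage points lower from compound 1 to compound 2 (within the scatter), changes the group on the carbonyl carbon and leaves the read-out where it was.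

Compound 3, `COc1ccc(C(=O)/C=C/c2cc(-c3cc(OC)c(OC)c(OC)c3)n[nH]2)cc1`, is not yet measured. It differs from compound 2 by hydrogen in place of methoxy on an aromatic carbon; cut one bond further out, the change reads 3,4-dimethoxyphenyl to 4-methoxyphenyl, again on the carbonyl carbon. The step from compound 1 to compound 2 bears on it, since it altered the same group in the same place, and it was within the scatter. For the measured compounds named here, no step here touches a methoxy group alone, so its weight is unknown. The expectation for compound 3 is therefore a step of a number 1 percentage points lower from compound 2 to compound 3 (within the scatter), that is none beyond the scatter. Compound 3 is estimated at 94%, within 84% to 104%.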

Compound 3, a percentage reported as activity, at one concentration (the size of the read-out at that concentration, not a potency): 95%
The estimate for compound 3 lay 1 percentage points below the measured number; the measured number falls inside the stated range.
By their numbers in this assay, from the lowest: compounds 2, 3 and 1 (each within the scatter of the next).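

In this assay, the methoxy group is now tested on its own, apart from any other change to the aryl group on the carbonyl carbon: no change at the digits printed from compound 2 to compound 3 (within the scatter). Hydrogen in place of this methoxy, on an aromatic carbon ortho to a methoxy group, therefore leaves no mark on the read-out at this single concentration, which the earlier pair, with its exchange of both substituents, could not show. The 4-methoxyphenyl group also cannot be separated from 3,4-dichlorophenyl at this place, a number 1 percentage points lower from compound 1 to compound 3 (within the scatter), so the three aryl groups at this carbonyl carbon give one undivided picture, and nothing measured speaks to the reason for it.

These compounds leave open whether any group on this ring can move the read-out in this assay, for instance an amine or a carboxylic acid in place of the remaining methoxy. They also leave open whether these three compounds would separate at a higher concentration, or whether changes elsewhere on the shared core would do so.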